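Ethyl in place of methyl ester, compound 3 to compound 4

The source may hold more compounds than are shown below. What is called first, only, known or untested is meant among the compounds shown, and "the series" means these compounds.

Three compounds of the series carry a number in a functional assay on HEK293 cells for antagonist activity at Voltage-dependent L-type calcium channel subunit alpha-1C (Oryctolagus cuniculus), read by FLIPR; on this read-out higher numbers stand for weaker inhibition and lower numbers for stronger inhibition. Compound 1 `CCOC(=O)C1=C(C)NC(/C=C/c2ccc([N+](=O)[O-])cc2)=C(C(=O)OCC)C1c1cccc([N+](=O)[O-])c1` gives 1940 nM. Compound 2 `C=CCOC(=O)C1=C(C)NC(C)=C(C(=O)OC)C1c1ccccc1[N+](=O)[O-]` gives 8 nM. Compound 3 `C=CCOC(=O)C1=C(C)NC(C)=C(C(=O)OC)C1c1cccc([N+](=O)[O-])c1` gives 15 nM. Among these numbers compound 3 stands second highest of three; its nearest neighbour is compound 2, with a gap that is within the scatter, a 1.9-fold higher number from compound 2 to compound 3 (0.27 log units; within the scatter), and its furthest is compound 1, whose number is far higher but which differs from compound 3 in several places at once, so no single step connects them.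

Compound 4 `C=CCOC(=O)C1=C(C)NC(C)=C(C(=O)OCC)C1c1cccc([N+](=O)[O-])c1` is not yet measured. It differs from compound 3 by methyl in place of hydrogen on a saturated chain carbon bound to an oxygen next to a carbonyl group; cut one bond further out the change reads methyl to ethyl, methoxy to ethoxy, methoxycarbonyl to ethoxycarbonyl. Within the data shown here, no measured pair shows this change. Among the measured compounds shown here, the only measured step, a 1.9-fold higher number from compound 2 to compound 3 (0.27 log units; within the scatter), concerns the nitrophenyl ring and lies within the scatter, so it says nothing about the ester. For the measured compounds named here, with no step bearing on the change, compound 4 is expected to show no shift beyond the scatter, an estimated step of no change at the digits printed from compound 3 to compound 4 (within the scatter). The estimate for compound 4 in this assay is 15 nM, with a range from 5 nM to 45 nM.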

Compound 4, half-maximal inhibitory concentration: 25 nM
Estimate against measurement, compound 4: 1.7-fold (0.22 log units) below, and the stated range covers the measured number.
By their numbers in this assay, from the lowest: compounds 2, 3 and 4 (each within the scatter of the next, the first and the last beyond it); then compound 1.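

In this assay, among these compounds, methyl in place of hydrogen on a saturated chain carbon bound to an oxygen next to a carbonyl group gives a 1.7-fold higher number from compound 3 to compound 4 (0.22 log units; within the scatter), the first reading of this ester position. At this place, methoxycarbonyl and ethoxycarbonyl cannot be told apart by this read-out, and the single added carbon produces no step beyond the scatter with the 3-nitrophenyl group held constant. The data shown contain no measurement that could explain this result.

From the compounds shown here alone, whether the position also accepts a much longer chain such as n-butyl, a ring-bearing ester such as benzyl, or a replacement such as a carboxylic acid or a primary amide remains open, as one added methyl is a short probe of this place. Also open, going by these compounds, is whether the methoxycarbonyl to ethoxycarbonyl change reads the same with 2-nitrophenyl in place of 3-nitrophenyl, as the present step rests on one pair in one assay.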